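The compounds below may be only part of what the source reports. "The series", "measured", "known", "first", "only" and "open" are said of these compounds alone.

Measured in an ADME assay on RAW264.7 cells (Mus musculus) for cytotoxicity, read by MTT assay, with a stated time of 24 h, in the absence of a further agent; on this read-out higher numbers stand for weaker inhibition and lower numbers for stronger inhibition:
- Compound 1 `O=C1OC(Cc2nc(-c3ccccc3)no2)c2ccccc21`: > 40000 nM
- Compound 2 `O=C1OC(Cc2nc(-c3ccc(Oc4ccccc4)cc3)no2)c2ccccc21`: > 40000 nM

Compound 2 stands at > 40000 nM, which is a limit of the assay and not a number. Compound 1 reads > 40000 nM, and this too is a limit. So no number is yet available in this series, and the evidence so far is the limit of > 40000 nM in this assay, at which 2 of the 2 values shown sit.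

Compound 3 `O=C1OC(Cc2nc(-c3ccc(-c4ccccc4)cc3)no2)c2ccccc21` keeps the shared core and differs from compound 2 in one place: phenyl in place of phenoxy on an aromatic carbon. This puts phenyl in place of phenoxy on an aromatic carbon, para to a large group.

Within the data shown here, the only measured step that bears on this change is a step that the two limits leave unreadable from compound 1 to compound 2. It gives no size to carry over, though neither compound left the limit. No step beyond the scatter is therefore expected in this assay, in either direction. The expected step is a number no higher from compound 2 to compound 3 (the limit leaves the size open). Compound 3 is estimated at 40000 nM, with an expected range from 20000 nM to 80000 nM. It is also expected that the assay will most likely report only a limit again.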

Compound 3, half-maximal inhibitory concentration: > 40000 nM
Compound 3 ended at the assay's limit (the forecaster's own chance of this, stated with the estimate: 85%); the middle value sits exactly at the limit.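

In this assay compound 3 gives > 40000 nM, which is a limit of the assay and not a number. No step among compound 1, compound 2 and compound 3 can be read, and the evidence remains: the limit of > 40000 nM in this assay, at which 3 of the 3 values shown sit.

The compounds shown leave open how far each lies from that limit, and whether phenoxy or phenyl changes the read-out at all.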